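Imidazole-linked dihydroxyheptenoic acids: aryl swap on the core

The compounds below may be only part of what the source reports. "The series", "measured", "known", "first", "only" and "open" are said of these compounds alone.

Measured compounds in an assay on isolated protein for inhibition of 3-hydroxy-3-methylglutaryl-coenzyme A reductase (Homo sapiens); a lower number here means a stronger inhibitor, a higher number a weaker inhibitor:
- compound 1, `Cc1nc(-c2ccc(F)cc2)c(-c2ccc(F)cc2)n1/C=C/[C@@H](O)C[C@@H](O)CC(=O)O`, < 7 nM
- compound 2, `CC(C)(C)c1nc(-c2ccc(F)cc2)c(-c2ccc(F)cc2)n1/C=C/[C@@H](O)C[C@@H](O)CC(=O)O`, 8.15 nM
- compound 3, `CC(C)c1nc(-c2ccc(F)cc2)c(-c2cc(Cl)cc(Cl)c2)n1/C=C/[C@@H](O)C[C@@H](O)CC(=O)O`, 7.66 nM

The value of compound 1 in this assay is a limit of the assay, not a number; this is the case described by the limit of < 7 nM in this assay, at which 1 of the 3 values shown sits. Compound 2 and compound 3 give the two numbers of the set, and they lie within the scatter of each other, so no order between them can be read.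

Compound 4, `Cc1cc(F)ccc1-c1c(-c2ccc(F)cc2)nc(C(C)C)n1/C=C/[C@@H](O)C[C@@H](O)CC(=O)O`, has not been measured. It differs from compound 3 by 4-fluoro-2-methylphenyl in place of 3,5-dichlorophenyl on an aromatic carbon.

For the measured compounds named here, the only measured step, an at least 1.1-fold higher number from compound 1 to compound 2 (0.06 log units; that floor lies within the scatter), changes the group on a different ring carbon and lies within the scatter; it does not speak to an aryl swap, and no measured pair compares two aryl groups at this position. Going by the values given here, the set shows only that three differently substituted members of the shared core give low numbers close together.

Without a measured step bearing on the change, no shift beyond the scatter is expected for compound 4, and the step of a 1.3-fold higher number from compound 3 to compound 4 (0.12 log units; within the scatter) is estimated as small. Compound 4 is therefore expected to give about 10 nM in this assay, with a range from 4 nM to 25 nM.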

Compound 4, half-maximal inhibitory concentration: 8.4 nM
Estimate against measurement, compound 4: 1.2-fold (0.08 log units) above; measured number inside the range.
By their numbers in this assay, from the lowest: compounds 3, 2 and 4 (each within the scatter of the next). At a limit, below all of these: compound 1.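

In this assay, for the compounds shown here, the change to 4-fluoro-2-methylphenyl from 3,5-dichlorophenyl, on the aromatic carbon next to the ring nitrogen, gives a 1.1-fold higher number from compound 3 to compound 4 (0.04 log units; within the scatter) and is the first measured pair comparing two aryl groups at this position. Two chlorine atoms on the phenyl ring thus give way to one fluorine atom and one methyl group, each aryl group having 8 heavy atoms, with no order readable between compound 3 and compound 4. Compound 1 remains a limit of the assay and not a number: the limit of < 7 nM in this assay, at which 1 of the 4 values shown sits.

As far as these compounds go, it remains open whether any aryl group at this position can move the number beyond the scatter, for instance an unsubstituted phenyl, a pyridine ring, or a phenyl ring carrying an amine or a carboxylic acid. Also open, from the compounds shown here alone, is whether the same swap would read the same way with methyl or tert-butyl in place of the isopropyl group, since this single pair carries isopropyl on both sides and speaks only for that setting.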